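Adding a Butyl Chain Where Compound 3 Carries Hydrogen

The source may hold more compounds than are shown below. What is called first, only, known or untested is meant among the compounds shown, and "the series" means these compounds.

Three compounds share one core and differ only on a single aromatic ring. Compound 3 `O=C1NCCN1c1ccc(S(=O)(=O)Nc2ccccc2)cc1` carries a hydrogen there, and in a functional assay on M21 cells (Homo sapiens) for antiproliferative activity, read by sulforhodamine B assay, with a stated time of 48 h (on this read-out lower numbers stand for stronger inhibition and higher numbers for weaker inhibition), compound 3 gives 200 nM. Compound 1 `COc1ccc(NS(=O)(=O)c2ccc(N3CCNC3=O)cc2)cc1` carries methoxy instead; in this assay compound 1 gives 580 nM. Compound 2 `CCCCCCOc1ccc(NS(=O)(=O)c2ccc(N3CCNC3=O)cc2)cc1` carries hexyloxy, and for compound 2 the this assay reports only a limit, > 1000 nM. Compound 3 thus holds the lowest of the two full numbers, with compound 1 nearest through a 2.9-fold lower number from compound 1 to compound 3 (0.46 log units; beyond the scatter).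

Compound 4 `CCCCc1ccc(NS(=O)(=O)c2ccc(N3CCNC3=O)cc2)cc1` differs from compound 3 by butyl in place of hydrogen on an aromatic carbon. Within the data shown here, three measured steps bear on this change. The step of a 2.9-fold lower number from compound 1 to compound 3 (0.46 log units; beyond the scatter) and the step of an at least 5.0-fold lower number from compound 2 to compound 3 (0.69 log units; beyond the scatter) both show the number falling when a group at this position is removed, and an at least 1.7-fold higher number from compound 1 to compound 2 (0.23 log units; that floor lies within the scatter) shows it rising when a chain is lengthened there. A butyl chain is closer in size to the hexyloxy of compound 2 than to the methoxy of compound 1, so a clear rise is expected. Compound 4 is therefore estimated at 900 nM, between 350 nM and 2500 nM. The expected step is a 4.5-fold higher number from compound 3 to compound 4 (0.65 log units; beyond the scatter).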

Compound 4, half-maximal inhibitory concentration: 450 nM
Compound 4: middle estimate off by 2.0-fold (0.30 log units), on the high side, and the stated range covers the measured number.
By their numbers in this assay, from the lowest: compound 3; then compounds 4 and 1 (each within the scatter of the next). At a limit, above all of these: compound 2.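

A chain attached to the ring through carbon, with no oxygen, also gives a weaker result than hydrogen, with a 2.3-fold higher number from compound 3 to compound 4 (0.35 log units; beyond the scatter), so the rise is not confined to the methoxy and hexyloxy groups, which are attached through oxygen. Butyl and methoxy cannot be told apart here, with a 1.3-fold lower number from compound 1 to compound 4 (0.11 log units; within the scatter), so the longer group carries no measurable extra cost over methoxy. Hexyloxy is still clearly worse than butyl, with an at least 2.2-fold lower number from compound 2 to compound 4 (0.34 log units; beyond the scatter), so the tolerated size at this ring carbon appears to end somewhere short of hexyloxy.

From the compounds shown here alone, how far compound 2 really lies from the others stays open, as its value is only a limit: the limit of > 1000 nM in this assay, at which 1 of the 4 values shown sits. Whether a shorter chain such as ethyl, an amine or a carboxylic acid on this ring carbon could match hydrogen also remains unknown.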